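This account rests on a few compounds, and the source may have more. Where it says the series, first, only, none or still open, it means among the compounds named here.

Three compounds have been measured so far in a functional assay for inhibition, read by spectrophotometry, with a stated time of 20 min, tested at 2 mg/mL; a lower number here means a weaker effect, a higher number a stronger effect of the compound at the concentration tested:

compound 1, `CC(=O)c1ccc(NC(=O)C(C(C)C)N(C(=O)c2ccccc2)S(=O)(=O)c2ccc([N+](=O)[O-])cc2)cc1`, gives 29.8%
compound 2, `CC(=O)c1ccc(NC(=O)C2CC(O)CN2S(=O)(=O)c2ccc([N+](=O)[O-])cc2)cc1`, gives 57%
compound 3, `CC(=O)c1ccc(NC(=O)C(C(C)C)N(C(=O)c2ccccc2)S(=O)(=O)c2ccccc2)cc1`, gives 41.3%

Compound 1 and compound 3 are built on one core, compound 2 on another; the difference between the two cores is not broken down here. Within the first core, the step of a number 11.5 percentage points higher from compound 1 to compound 3 (beyond the scatter) accompanies the change (hydrogen in place of nitro on an aromatic carbon). Compound 2 gives the highest of the three numbers in this assay, and its distance to compound 3 and to compound 1 lies beyond the scatter in both cases.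

Compound 4, `CC(=O)c1ccc(NC(=O)C2CC(O)CN2S(=O)(=O)c2ccccc2)cc1`, has not yet been measured. It differs from compound 2 by hydrogen in place of nitro on an aromatic carbon, the same change that turns compound 1 into compound 3; the place of the change reads the same in both pairs. Across all four compounds this change occurs twice, once measured and once not.

Compound 4 is therefore expected to move in the same direction as that earlier step, and the expected step of a number 11 percentage points higher from compound 2 to compound 4 (beyond the scatter) in this assay rests on a single precedent, the step of a number 11.5 percentage points higher from compound 1 to compound 3 (beyond the scatter) on a different core. Compound 4 is estimated at 68% in this assay. Compound 4 is expected to fall between 50% and 84%, the range being wide since one earlier instance is a thin basis.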

Compound 4, a percentage reported as inhibition, at one concentration (the size of the read-out at that concentration, not a potency): 45%
Estimate against measurement, compound 4: 23 percentage points above, and the stated range ends above it.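

On the core of compound 2, the change from 4-nitrophenyl to phenyl goes with a number 12 percentage points lower from compound 2 to compound 4 (beyond the scatter) in this assay, so the nitro group's replacement by hydrogen does not keep its direction when carried over from the core of compound 1. Set side by side, the two instances of this one change run in opposite directions, and the gap between them is larger than scatter alone would account for: the same change on two cores in this assay, a number 11.5 percentage points higher (beyond the scatter) from compound 1 to compound 3 and a number 12 percentage points lower (beyond the scatter) from compound 2 to compound 4, 23.5 percentage points apart, beyond the scatter of two such steps. Among these compounds, this shows that, in this series, a step seen on one core cannot be transferred to the other even as to its sign, but it rests on only two pairs and does not show which feature of the cores goes with the reversal, nor what the change would do on any third core.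

The compounds shown leave open whether an amine, a carboxylic acid or a methoxy group in the place of the nitro group, on an aromatic carbon para to a large group, would follow the pattern of one core on both. They also leave open which part of the two cores matters, since no compound shown separates the benzoyl group from the hydroxyl group.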